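The source may report more compounds than this note shows. Statements on the series, on what has been measured and on what is new or still open speak of the compounds shown alone.

Of the compounds shown here, three from this series have been tested so far. Compound 1 `Cc1ccc(NC(=S)NC(=O)c2ccc(OCc3ccc(Cl)cc3Cl)cc2)cc1-c1nc2ccccc2[nH]1` gives 3450 nM in a functional assay on MGC-803 cells (Homo sapiens) for inhibition, read by MTT assay, with a stated time of 48 h; on this read-out lower numbers stand for stronger inhibition and higher numbers for weaker inhibition. Compound 2 `Cc1ccc(NC(=S)NC(=O)c2ccc(OCc3ccc(F)cc3)cc2)cc1-c1nc2ccccc2[nH]1` carries 4-fluorophenyl in place of 2,4-dichlorophenyl on a saturated chain carbon bound to an oxygen on an aromatic ring, and in this assay compound 2 gives 2810 nM; this is a 1.2-fold lower number from compound 1 to compound 2 (0.09 log units; within the scatter). Compound 3 `Cc1ccc(NC(=O)NC(=O)c2ccc(OCc3ccc(Cl)cc3Cl)cc2)cc1-c1nc2ccccc2[nH]1` rests on a different core, and how that core differs from the core of compound 1 is not broken down here. In this assay compound 3 gives 2740 nM, a value that sits alongside those of compound 1 and compound 2 without any of the three standing apart.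

Compound 4 `Cc1ccc(NC(=O)NC(=O)c2ccc(OCc3ccc(F)cc3)cc2)cc1-c1nc2ccccc2[nH]1` has not yet been measured. It is built from compound 3 by 4-fluorophenyl in place of 2,4-dichlorophenyl on a saturated chain carbon bound to an oxygen on an aromatic ring, the same change that separates compound 1 from compound 2, at the same place. Because that earlier change gave a 1.2-fold lower number from compound 1 to compound 2 (0.09 log units; within the scatter), the step from compound 3 to compound 4 is expected to be of a similar small size, a 1.2-fold lower number from compound 3 to compound 4 (0.08 log units; within the scatter). On this basis compound 4 is estimated to give about 2300 nM in this assay, with a likely range from 1200 nM to 4500 nM.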

Compound 4, half-maximal inhibitory concentration: 160 nM
For compound 4 the middle estimate is 14-fold (1.16 log units) above the measured one; the measured number lies below the stated range.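

In this assay, the change from 2,4-dichlorophenyl to 4-fluorophenyl, on a saturated chain carbon bound to an oxygen on an aromatic ring, gives a 17-fold lower number from compound 3 to compound 4 (1.23 log units; beyond the scatter). Set beside the same change on the core of compound 1, the step does not carry over at the same size: the same change on two cores in this assay, a 1.2-fold lower number (0.09 log units; within the scatter) from compound 1 to compound 2 and a 17-fold lower number (1.23 log units; beyond the scatter) from compound 3 to compound 4, 14-fold (1.14 log units) apart, beyond the scatter of two such steps. This shows that, among these four compounds, the size of the step depends on the core that carries it, but with one pair on each core it does not show why, nor does it give a rule for any other core in the series.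

The compounds shown leave open whether the large step belongs to the loss of the two chlorines, the gain of the fluorine or the two together. They also leave open how an amine, a carboxylic acid or a longer chain at the same place would read out on either core.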